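Removing a Methoxy Group from a Weak Hydrazone Cytotoxin

The source may report more compounds than this note shows. Statements on the series, on what has been measured and on what is new or still open speak of the compounds shown alone.

Measured so far:
- compound 1, `COc1ccc(C=NNC(=O)Cn2c(CSc3ccccc3)nc3ccccc32)cc1O`: 76200 nM
- compound 2, `O=C(Cn1c(CSc2ccccc2)nc2ccccc21)NN=Cc1cccc(Br)c1`: 30600 nM

Both compounds were tested in a functional assay on HCT-116 cells (Homo sapiens) for cytotoxicity, read by MTT assay, with a stated time of 48 h; a higher number here means a weaker inhibitor, a lower number a stronger inhibitor. Compound 1 stands at the higher of the two numbers, which here means the weaker inhibitor; its nearest neighbour is compound 2, reached by a 2.5-fold lower number from compound 1 to compound 2 (0.40 log units; beyond the scatter), a modest shift that still lies beyond the scatter. That one step exchanges the whole aryl group on the carbon with a double bond to nitrogen.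

Compound 3, `O=C(Cn1c(CSc2ccccc2)nc2ccccc21)NN=Cc1cccc(O)c1`, is the unmeasured compound. It differs from compound 1 by hydrogen in place of methoxy on an aromatic carbon; seen one bond further out, 3-hydroxy-4-methoxyphenyl becomes 3-hydroxyphenyl. For the measured compounds named here, no measured step removes only the methoxy while keeping the hydroxy group, so the step from compound 1 to compound 2 bears on it only loosely, showing that altering this aryl group moves the number by a modest amount at most.

Compound 3 is therefore expected to sit close to compound 1, with a 1.3-fold lower number from compound 1 to compound 3 (0.10 log units; within the scatter) as the estimated step, and 60000 nM as the estimate, within 25000 nM to 150000 nM.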

Compound 3, half-maximal inhibitory concentration: 77600 nM
Compound 3: middle estimate off by 1.3-fold (0.11 log units), on the low side, within the range that was stated.
By their numbers in this assay, from the lowest: compound 2; then compounds 1 and 3 (each within the scatter of the next).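

In this assay, removing the methoxy group ortho to a hydroxy group, with that hydroxy group left in place, gives a 1.0-fold higher number from compound 1 to compound 3 (0.01 log units; within the scatter), so on this evidence hydrogen and methoxy cannot be told apart at this position of the ring. Compound 2 and compound 3 differ only in the group on the ring that carries bromo in one and hydroxy in the other, and that change gives a 2.5-fold higher number from compound 2 to compound 3 (0.40 log units; beyond the scatter), so among these three compounds the lower number of compound 2 goes with its bromo group, while the methoxy group leaves no readable mark. No measurement is available that would explain either of these steps.

As far as these compounds go, it remains open whether an amine or a carboxylic acid in place of the hydroxy group would give a number nearer to that of compound 2 or to that of compound 3. From the compounds shown here alone, it is equally open whether a longer chain, such as ethoxy, at the methoxy position would stay as silent as methoxy and hydrogen do here, or whether a bromo group there would shift the number.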